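Swapping the aryl substituent on a furanylmethyl-amine quinoline core

The source may report more compounds than this note shows. Statements on the series, on what has been measured and on what is new or still open speak of the compounds shown alone.

Of the compounds shown here, two built on the same core have been measured in a physicochemical assay for acid dissociation. Compound 1 `COc1ccc(-c2ccc3c(NCCCNCc4ccco4)ccnc3c2)cc1` carries a 4-methoxyphenyl group, and in this assay compound 1 gives 9.47. Compound 2 `COc1ccc(Oc2ccc3c(NCCCNCc4ccco4)ccnc3c2)cc1` carries a 4-methoxyphenoxy group instead, and in this assay compound 2 gives 9.28. For the measured compounds named here, the change a number 0.19 log units lower from compound 1 to compound 2 (within the scatter) is the only measured step, and its size says that replacing one aryl group by another at this position left the proton given up about as readily as before. Compound 2 stands lowest of the two numbers, with compound 1 its nearest neighbour and the gap between them within the scatter.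

Compound 3 `Fc1ccc(Cc2ccc3c(NCCCNCc4ccco4)ccnc3c2)cc1` is not yet measured. It differs from compound 2 in one place: 4-fluorobenzyl in place of 4-methoxyphenoxy on an aromatic carbon. The measured step from compound 1 to compound 2 bears on this exchange only loosely, since a different group enters here, but it was within the scatter. For compound 3 the expected step is a number 0.12 log units higher from compound 2 to compound 3 (within the scatter), which is no step beyond the scatter. Compound 3 is therefore estimated at 9.4, between 9 and 9.8.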

Compound 3, acid dissociation constant: 9.47
Estimate against measurement, compound 3: 0.07 log units below; the range from low to high includes it.
By their numbers in this assay, from the lowest: compounds 2, 1 and 3 (each within the scatter of the next).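

Exchanging 4-methoxyphenoxy for 4-fluorobenzyl in this assay gives a number 0.19 log units higher from compound 2 to compound 3 (within the scatter) even though the entering group counts 0 hydrogen-bond acceptors and the leaving group counts 2. Exchanging 4-methoxyphenyl for 4-fluorobenzyl gives no change at the digits printed from compound 1 to compound 3 (within the scatter) and so adds a second step within the scatter, which means that all three groups at this aromatic carbon now read alike in this measurement, whether or not oxygen is present in the group. No measurement offered here explains why the number holds so steady across these exchanges.

All three groups carry a six-membered aromatic ring of carbon only, so these compounds leave open whether an amine, a carboxylic acid or a longer chain at this aromatic carbon would give a step beyond the scatter. They also leave open which site on the shared core gives up the proton, and whether other places on that core would respond as little as this one has.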